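Swapping dimethylamino for 4-methylpiperazin-1-yl on compound 2

A few compounds are considered here, and "the series" means these few. Any claim that something is new, unique, unknown or untested is made for them only; others in the source may bear on it.

Measured compounds in a functional assay on SK-BR-3 cells (Homo sapiens) for antiproliferative activity, read by MTT assay, with a stated time of 72 h; on this read-out higher numbers stand for weaker inhibition and lower numbers for stronger inhibition
Compound 1 (`CCN1CCN(c2cc(C)c3cc(NC(=O)c4cccnc4)ccc3n2)CC1`) gives 10600 nM
Compound 2 (`Cc1cc(NCCN(C)C)nc2ccc(NC(=O)c3ccc(Cl)c(Cl)c3)cc12`) gives 6670 nM
Compound 3 (`CCN1CCN(c2cc(C)c3cc(NC(=O)c4cc(Cl)cc(Cl)c4)ccc3n2)CC1`) gives 2660 nM

Compound 2, at 6670 nM in this set, lies within the scatter of compound 1, at 10600 nM here, so the two cannot be told apart. Compound 3, at 2660 nM on the same read-out, gives a lower number than compound 2, beyond the scatter, but those two differ in more than one place and their gap isolates no single change.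

The change from compound 2 to compound 4 (`Cc1cc(NCCN2CCN(C)CC2)nc2ccc(NC(=O)c3ccc(Cl)c(Cl)c3)cc12`) is 4-methylpiperazin-1-yl in place of dimethylamino on a saturated chain carbon, two bonds along the chain from a nitrogen on an aromatic ring and it sits on a saturated chain carbon, two bonds along the chain from a nitrogen on an aromatic ring. Going by the values given here, the only measured step is a 4.0-fold lower number from compound 1 to compound 3 (0.60 log units; beyond the scatter) and it is modest. It concerns 3,5-dichlorophenyl in place of pyridin-3-yl on a carbonyl carbon, a different place, so it says little here. Among the compounds with values here, no measured step touches the chain, and the data give no direction for this change. The step expected in this assay is therefore a 1.3-fold lower number from compound 2 to compound 4 (0.13 log units; within the scatter) and it is not expected to exceed the scatter. For compound 4 the estimated value is 5000 nM with an expected range from 1800 nM to 14000 nM in this measurement.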

Compound 4, half-maximal inhibitory concentration in the SK-BR-3 assay: 2690 nM
Compound 4: the middle estimate sits 1.9-fold (0.27 log units) above what was measured, and the stated range covers the measured number.
By their numbers in the SK-BR-3 assay, from the lowest: compounds 3 and 4 (each within the scatter of the next); then compounds 2 and 1 (each within the scatter of the next).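

In the SK-BR-3 assay the group at the end of the chain proves able to move the number: compound 2 gives 6670 nM and compound 4 gives 2690 nM. Going by these compounds alone, in the SK-BR-3 assay 4-methylpiperazin-1-yl in place of dimethylamino gives a 2.5-fold lower number from compound 2 to compound 4 (0.39 log units; beyond the scatter) and is the first measured step at this position, since the earlier step concerned only the group on the carbonyl carbon. In a physicochemical assay for lipophilicity, at pH 7.4 (on this read-out higher numbers stand for higher lipophilicity and lower numbers for lower lipophilicity), compound 2 gives 1.47 and compound 4 gives 1.73. In the physicochemical assay the same change gives a number 0.26 log units higher from compound 2 to compound 4 (within the scatter) and so does not separate the two compounds, although they are separated in the SK-BR-3 assay by a step beyond the scatter. Nothing available accounts for the lower number with the ring-bearing group.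

The pair leaves open whether the step depends on the ring itself, on its second nitrogen or on the methyl group on that nitrogen, and a morpholin-4-yl, piperidin-1-yl or unsubstituted piperazin-1-yl group at the same place would address those possibilities. It also leaves open whether the step would persist on a longer chain, or with the 3,5-dichlorophenyl or pyridin-3-yl group on the carbonyl carbon in place of the dichlorophenyl group that compound 2 and compound 4 share.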